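Cyclohexyl in place of phenyl on the amide side chain

A few compounds are considered here, and "the series" means these few. Any claim that something is new, unique, unknown or untested is made for them only; others in the source may bear on it.

Compound 2 `Cc1nc(N)sc1CCCNC(=N)NC(=O)C[C@H](C)c1ccccc1` is the reference point here. For the measured compounds named here, in an in vitro functional assay on Sf9 cells for agonist activity at histamine H2 receptor (Cavia porcellus), read by GTPgammaS binding (on this read-out higher numbers stand for an effect only at larger amounts of compound and lower numbers for an effect already at smaller amounts), compound 2 gives 7.76 nM, the lowest of the two numbers measured so far; the nearest is compound 1 `Cc1nc(N)sc1CCCNC(=N)NC(=O)C[C@H](C)C1CCCCC1`, which in this assay gives 14.1 nM, and the two lie within the scatter of each other. Compound 3 `Cc1nc(N)sc1CCCNC(=N)NC(=O)C[C@@H](C)C1CCCCC1` has not yet been measured. It differs from compound 2 by 1-cyclohexylethyl in place of 1-phenylethyl on a saturated chain carbon bound to a carbonyl carbon. Going by the values given here, compound 3 shares its connectivity with compound 1 and differs from it only in the defined stereocentre, for which no measured step exists. Among the compounds with values here, the one step that bears on the change is the ring swap in a 1.8-fold lower number from compound 1 to compound 2 (0.26 log units; within the scatter), which is within the scatter. Going back from phenyl to cyclohexyl is therefore expected to move the number little, if at all; the stereocentre remains an open point and widens the range. For compound 3 the expected step is a 1.9-fold higher number from compound 2 to compound 3 (0.29 log units; within the scatter) in this assay, and the estimate for compound 3 is 15 nM, with a range from 5 nM to 50 nM.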

Compound 3, half-maximal effective concentration: 13.2 nM
The estimate for compound 3 lay 1.1-fold (0.06 log units) above the measured number, and the stated range covers the measured number.
By their numbers in this assay, from the lowest: compounds 2, 3 and 1 (each within the scatter of the next).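

In this assay, the replacement of 1-phenylethyl by 1-cyclohexylethyl on a saturated chain carbon bound to a carbonyl carbon now has a second reading, a 1.7-fold higher number from compound 2 to compound 3 (0.23 log units; within the scatter), and like the earlier ring step it lies within the scatter. The stereocentre, the open point until now, gives no separation either: a 1.1-fold lower number from compound 1 to compound 3 (0.03 log units; within the scatter), with the centre drawn S in compound 1 and R in compound 3. So among these three compounds, neither the change from an aromatic to a non-aromatic six-membered carbon ring nor the drawn configuration separates the numbers, though one limit applies to reading compound 1 and compound 3 as a clean pair of configurations: the fact that one of compounds 1 and 3 is drawn with a defined configuration and the other without, at the place where they differ.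

Still open, as far as these compounds go, is whether this flat picture holds beyond six-membered carbon rings, for example with an amine, a carboxylic acid or a longer chain in place of 1-cyclohexylethyl on that carbon. Also open, from the compounds shown here alone, is how the opposite configuration at that carbon reads with 1-phenylethyl in place.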